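A Small Exchange on the Carbonyl-Bound Oxygen

The compounds below may be only part of what the source reports. "The series", "measured", "known", "first", "only" and "open" are said of these compounds alone.

Of the compounds shown here, two have been measured in a functional assay on isolated protein for agonist activity at Glucose-dependent insulinotropic receptor (Homo sapiens), read by HTRF and cAMP accumulation; a higher number here means that more compound is needed for the effect, a lower number that less compound is needed. Compound 1 `CC(C)(C)OC(=O)N1CCC(O[C@H]2CC[C@H](Oc3cnc(C#N)cn3)CC2)CC1` gives 8.3 nM. Compound 2 `CC1(OC(=O)N2CCC(O[C@H]3CC[C@H](Oc4cnc(S(C)(=O)=O)cn4)CC3)CC2)CC1` gives 25.9 nM, the higher of the two numbers, and its gap to compound 1 lies beyond the scatter. Compound 3 `C[C@@H](CF)OC(=O)N1CCC(O[C@H]2CC[C@H](Oc3cnc(S(C)(=O)=O)cn3)CC2)CC1` differs from compound 2 only by 1-(fluoromethyl)ethyl in place of 1-methylcyclopropyl on an oxygen next to a carbonyl group. Among the measured compounds shown here, no measured pair shows what this exchange does in this assay, so the estimate rests on compound 2 alone, and the step from compound 2 to compound 3 is expected to be a 1.3-fold lower number from compound 2 to compound 3 (0.11 log units; within the scatter), most likely within the scatter. Compound 3 is expected to give 20 nM, in a range from 7 nM to 60 nM.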

Compound 3, half-maximal effective concentration: 31.1 nM
Compound 3: the middle estimate sits 1.6-fold (0.19 log units) below what was measured; the measured number falls inside the stated range.
By their numbers in this assay, from the lowest: compound 1; then compounds 2 and 3 (each within the scatter of the next).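

In this assay, placing 1-(fluoromethyl)ethyl in place of 1-methylcyclopropyl on an oxygen next to a carbonyl group gives a 1.2-fold higher number from compound 2 to compound 3 (0.08 log units; within the scatter). This position therefore tolerates losing the three-membered ring and gaining a fluorine and a defined stereocentre, with no readable change in the number. Nothing available explains why these two groups read alike. 

Still open, going by these compounds, is whether the mirror-image form of 1-(fluoromethyl)ethyl would read the same. Also open, on these data alone, is what a more different group on this oxygen, such as a longer chain or an amine, would do.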